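Swapping an Allylcarbamoyl for a Bromophenylsulfonyl Group

The source may hold more compounds than are shown below. What is called first, only, known or untested is meant among the compounds shown, and "the series" means these compounds.

Compound 1 `C=CCNC(=O)n1c(-c2ccc(OC)cc2)cc(=O)c2c(OC)cc(OC)cc21` was tested in an ADME assay on BJ cells (Homo sapiens) for antiproliferative activity, with a stated time of 72 h; on this read-out higher numbers stand for an effect only at larger amounts of compound and lower numbers for an effect already at smaller amounts. In this assay compound 1 gives 74000 nM. Compound 2 `COc1ccc(-c2c(Br)c(=O)c3c(OC)cc(OC)cc3n2S(=O)(=O)c2ccc(OC)cc2)cc1`, which also carries a sulfonyl group, gives 49700 nM in this assay, and the two numbers lie within the usual scatter of each other, so neither can be called more or less active than the other. Compound 3 `COC(=O)c1cc(=O)c2c(OC)cc(OC)cc2n1C` reached only > 37900 nM in this assay, which is a limit of the assay rather than a number (the limit of > 37900 nM in this assay, at which 1 of the 3 values shown sits).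

Compound 4 `COc1ccc(-c2cc(=O)c3c(OC)cc(OC)cc3n2S(=O)(=O)c2cccc(Br)c2)cc1` has not yet been measured. It differs from compound 1 in one place: (3-bromophenyl)sulfonyl in place of allylcarbamoyl on an aromatic nitrogen. For the measured compounds named here, no measured pair shows this exact change, so its effect can only be judged from what the measured compounds show. Compound 2, a related sulfonyl compound, gives 49700 nM, close to what compound 1 gives, and this suggests that replacing the allylcarbamoyl group with a sulfonyl group leaves the read-out roughly where it was. The step is expected to be a 1.3-fold lower number from compound 1 to compound 4 (0.13 log units; within the scatter), with no direction beyond the scatter. Compound 4 is therefore estimated at 55000 nM, with a range from 18000 nM to 170000 nM.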

Compound 4, half-maximal effective concentration: > 58600 nM
Compound 4: only a limit was reported; the forecaster's own chance of this, stated with the estimate: 30%; middle value at least 1.0-fold (0.02 log units) away from the limit.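

In this assay compound 4 gives > 58600 nM and this is a limit of the assay, not a number. The step from compound 1 to compound 4 therefore cannot be read: the limit of > 58600 nM in this assay, at which 1 of the 4 values shown sits. The compounds shown leave open whether (3-bromophenyl)sulfonyl in place of allylcarbamoyl on the aromatic nitrogen changes the read-out at all, and in which direction.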